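Swapping Bromo for Methoxy on a Conjugated Dienone

A few compounds are considered here, and "the series" means these few. Any claim that something is new, unique, unknown or untested is made for them only; others in the source may bear on it.

Three compounds have so far been measured in a functional assay on Hep cells (Homo sapiens) for cytotoxicity, read by sulforhodamine B assay, with a stated time of 48 h; a higher number here means a weaker inhibitor, a lower number a stronger inhibitor:

Compound 1, `CC1=C(/C=C/C(=O)/C=C/c2ccccc2)C(C)(C)CCC1`: 62200 nM
Compound 2, `CC1=C(/C=C/C(=O)/C=C/c2ccc(Br)cc2)C(C)(C)CCC1`: 34500 nM
Compound 3, `CC1=C(/C=C/C(=O)/C=C/c2ccc(F)cc2)C(C)(C)CCC1`: 55800 nM

All three share one core and differ only in the group on the aromatic ring. Compound 2 has the smallest of the three numbers, but the gaps to its neighbours are small: a 1.6-fold higher number from compound 2 to compound 3 (0.21 log units; within the scatter) and, in the other direction, a 1.8-fold lower number from compound 1 to compound 2 (0.26 log units; within the scatter). Both lie within the scatter, so the three compounds cannot be told apart on these data.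

Compound 4, `COc1ccc(/C=C/C(=O)/C=C/C2=C(C)CCCC2(C)C)cc1`, has not been measured. It differs from compound 2 in one place: methoxy in place of bromo on an aromatic carbon. Going by the values given here, the steps that bear on this change are the earlier swaps at the same aromatic carbon: a 1.8-fold lower number from compound 1 to compound 2 (0.26 log units; within the scatter), a 1.1-fold lower number from compound 1 to compound 3 (0.05 log units; within the scatter) and a 1.6-fold higher number from compound 2 to compound 3 (0.21 log units; within the scatter). None of them goes beyond the scatter, so no change in this assay beyond the scatter is expected here either; the expected step is a 1.3-fold higher number from compound 2 to compound 4 (0.12 log units; within the scatter). Compound 4 is therefore estimated at 45000 nM, with a likely range from 20000 nM to 100000 nM.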

Compound 4, half-maximal inhibitory concentration: > 100000 nM
Compound 4 was reported as a limit (the forecaster's own chance of this, stated with the estimate: 5%); middle value at least 2.2-fold (0.34 log units) from the limit.
By their numbers in this assay, from the lowest: compounds 2, 3 and 1 (each within the scatter of the next). At a limit, above all of these: compound 4.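

In this assay, compound 4 is recorded only as a limit, > 100000 nM. Even so, this is the first change on this aromatic carbon, para to a large group, that carries the number beyond the scatter, and the step is at least modest (an at least 2.8-fold higher number from compound 2 to compound 4 (0.46 log units; beyond the scatter)). The position is therefore not indifferent to its group, although hydrogen, fluoro and bromo could not be told apart there. The other two steps to compound 4 have floors within the scatter and cannot be read (an at least 1.7-fold higher number from compound 3 to compound 4 (0.25 log units; that floor lies within the scatter) and an at least 1.6-fold higher number from compound 1 to compound 4 (0.20 log units; that floor lies within the scatter)).

From the compounds shown here alone, how large the step to compound 4 truly is remains unknown. Also open, going by these compounds, is whether an amine or a hydroxyl on the same carbon, or a longer chain such as ethoxy in place of methoxy, would shift the number in the same direction.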